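Benzyl for pyridin-2-yl: a step from compound 1

The compounds below may be only part of what the source reports. "The series", "measured", "known", "first", "only" and "open" are said of these compounds alone.

Measured in an assay for inhibition of Alpha amylase (Homo sapiens), read by spectrophotometry, with stated times of 10 min and 20 min; a higher number here means a weaker inhibitor, a lower number a stronger inhibitor:
compound 1 `CCn1nc(Cn2nnc(-c3ccccn3)n2)cc1C` gives 540 ug/mL
compound 2 `Cc1cc(Cn2nnc(-c3ccccn3)n2)n[nH]1` gives 950 ug/mL

Compound 1 holds the lowest of the two numbers; its nearest neighbour is compound 2, with a 1.8-fold higher number from compound 1 to compound 2 (0.25 log units; within the scatter). Compound 3 `CCn1nc(Cn2nnc(Cc3ccccc3)n2)cc1C` differs from compound 1 by benzyl in place of pyridin-2-yl on an aromatic carbon. Among the compounds with values here, the only measured step, hydrogen in place of ethyl on an aromatic nitrogen, touches another part of the shared core and is within the scatter, so no measured step bears on this change. The expectation for compound 3 is therefore no step beyond the scatter, estimated at 700 ug/mL within 300 ug/mL to 1600 ug/mL, meaning a 1.3-fold higher number from compound 1 to compound 3 (0.11 log units; within the scatter).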

Compound 3, half-maximal inhibitory concentration in the Alpha amylase assay: 2360 ug/mL
The estimate for compound 3 lay 3.4-fold (0.53 log units) below the measured number, outside the stated range (above it).
By their numbers in the Alpha amylase assay, from the lowest: compounds 1 and 2 (each within the scatter of the next); then compound 3.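

At this aromatic carbon, benzyl in place of pyridin-2-yl gives in the Alpha amylase assay a 4.4-fold higher number from compound 1 to compound 3 (0.64 log units; beyond the scatter), so the series responds here beyond the scatter, which the step on the aromatic nitrogen did not show. The weaker inhibition comes with one hydrogen-bond acceptor fewer. In a physicochemical assay for lipophilicity (on this read-out lower numbers stand for lower lipophilicity and higher numbers for higher lipophilicity), compound 1 gives 2.08 and compound 3 gives 2.88. Higher lipophilicity accompanies it, so here a rise in lipophilicity does not go with stronger inhibition: the measured partition coefficient of compound 1, 2.08, and of compound 3, 2.88, a number 0.80 log units higher (beyond the scatter)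

The compounds shown do not separate the loss of the ring nitrogen from the added carbon of benzyl. Phenyl at this carbon would bear on that question.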